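The source may report more compounds than this note shows. Statements on the series, on what has been measured and on what is new or still open speak of the compounds shown alone.

Of the compounds shown here, three sharing one core have been measured in a functional assay on MCF7 cells (Homo sapiens) for cytotoxicity, read by MTT assay, with a stated time of 96 h; on this read-out lower numbers stand for stronger inhibition and higher numbers for weaker inhibition. Compound 1 (`COc1cc(C(=O)c2cn(-c3ccccc3)cc2-c2ccccc2Cl)cc(OC)c1OC`) gives 76 nM, compound 2 (`COc1cc(C(=O)c2cn(-c3cccc(N)c3)cc2-c2ccccc2Cl)cc(OC)c1OC`) gives 40 nM and compound 3 (`COc1cc(C(=O)c2cn(-c3ccc(F)cc3)cc2-c2ccccc2Cl)cc(OC)c1OC`) gives 83 nM. Two comparisons place compound 3 among them: a 1.1-fold higher number from compound 1 to compound 3 (0.04 log units; within the scatter), and a 2.1-fold higher number from compound 2 to compound 3 (0.32 log units; beyond the scatter). It therefore sits level with compound 1, and only its gap to compound 2 clears the usual scatter, and then only modestly.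

Compound 4 (`COc1cc(C(=O)c2cn(-c3ccc(F)cc3)cc2-c2ccc(N)cc2)cc(OC)c1OC`) carries 4-aminophenyl in place of 2-chlorophenyl on an aromatic carbon, and its 4-fluorophenyl group stays as it is: 4-aminophenyl in place of 2-chlorophenyl on an aromatic carbon. For the measured compounds named here, no measured step changes this place, so the available evidence is indirect. Compound 2 carries an amino group at a different place, and adding it gave a 1.9-fold lower number from compound 1 to compound 2 (0.28 log units; within the scatter). Compound 3 carries a fluoro group, and adding it gave a 1.1-fold higher number from compound 1 to compound 3 (0.04 log units; within the scatter). Neither step lies beyond the scatter, and the one gap that does is modest. As far as these compounds go, a small step toward a lower number in this assay is therefore the expectation, though the removal of the 2-chlorophenyl group remains untested. The expected change is a 1.4-fold lower number from compound 3 to compound 4 (0.14 log units; within the scatter). For compound 4, the estimated value is 60 nM, with an expected range from 15 nM to 250 nM.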

Compound 4, half-maximal inhibitory concentration: 12 nM
The estimate for compound 4 lay 5.0-fold (0.70 log units) above the measured number; measured number outside the range, below it.
By their numbers in this assay, from the lowest: compound 4; then compounds 2, 1 and 3 (each within the scatter of the next, the first and the last beyond it).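

In this assay, putting 4-aminophenyl in place of 2-chlorophenyl gives a 6.9-fold lower number from compound 3 to compound 4 (0.84 log units; beyond the scatter) and is the largest single step among these four compounds. For the compounds shown here, the earlier compounds all kept 2-chlorophenyl on this aromatic carbon and differed only in the group on the ring nitrogen, where the steps stayed within the scatter or only just beyond it, so this position is the first to show that one change can move the number well beyond the scatter. Nothing measured here accounts for the size of this step.

This single swap removes the chlorine and adds the amino group at another place on the phenyl ring, so the compounds shown cannot say whether losing the one, gaining the other, or the pairing of both produces the step. An unsubstituted phenyl, a 4-chlorophenyl or a 2-aminophenyl group at this position would separate those possibilities, and a 4-hydroxyphenyl or 4-methoxyphenyl group would test whether the amino group itself is needed.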